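Adding one methoxy group to compound 1

The source may hold more compounds than are shown below. What is called first, only, known or untested is meant among the compounds shown, and "the series" means these compounds.

Measured so far in a functional assay on B16 cells (Mus musculus) for antiproliferative activity, read by MTT assay, with a stated time of 72 h; a lower number here means a stronger inhibitor, a higher number a weaker inhibitor:
- compound 1 `COc1ccc(/C=C(/c2cc(OC)c(OC)c(OC)c2)C(C)O)cc1OC` gives > 100000 nM, a limit
- compound 2 `COc1ccc(/C=C(/c2cc(OC)c(OC)c(OC)c2)C(C)O)cc1O` gives 16100 nM
- compound 3 `COc1ccc(/C=C(/c2cc(OC)c(OC)c(OC)c2)C(C)O)cc1[N+](=O)[O-]` gives > 100000 nM, a limit

Compound 1 has no number, only a limit, and it shares that position with compound 3: the limit of > 100000 nM in this assay, at which 2 of the 3 values shown sit. The next candidate, compound 4 `COc1cc(/C=C(/c2cc(OC)c(OC)c(OC)c2)C(C)O)cc(OC)c1OC`, differs from compound 1 by methoxy in place of hydrogen on an aromatic carbon. This is methoxy in place of hydrogen on an aromatic carbon, ortho to a methoxy group.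

Among the compounds with values here, no measured step makes this exact change. The nearest evidence comes from changes on the same ring. Exchanging methoxy for hydroxy gives an at least 6.2-fold lower number from compound 1 to compound 2 (0.79 log units; beyond the scatter), and exchanging hydroxy for nitro gives an at least 6.2-fold higher number from compound 2 to compound 3 (0.79 log units; beyond the scatter). Exchanging methoxy for nitro gives a step that the two limits leave unreadable from compound 1 to compound 3, which adds nothing on size.

Within this small set, only compound 2, at 16100 nM, gives a measured number, and it alone carries a hydroxy group. Compound 4 has no hydroxy group and gains only a further methoxy, so no clear gain is expected in this assay, and a reading at the limit is the likeliest outcome. The expected step is a number no higher from compound 1 to compound 4 (the limit leaves the size open). For compound 4 the estimated value is 100000 nM, with an expected range from 30000 nM to 200000 nM.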

Compound 4, half-maximal inhibitory concentration: 84000 nM
Compound 4: middle estimate off by 1.2-fold (0.08 log units), on the high side; the range from low to high includes it.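

In this assay, within the data shown here, methoxy in place of hydrogen on an aromatic carbon, ortho to a methoxy group, gives an at least 1.1-fold lower number from compound 1 to compound 4 (0.07 log units; that floor lies within the scatter), the first direct reading of a change at this position. Compound 4 gives a number, 84000 nM, and carries no hydroxy group, so a measured number in this series no longer belongs to the hydroxy-bearing compound 2 alone. Compound 1 remains a limit, so the change has only a floor and no measured size, and compound 3 shares that position: the limit of > 100000 nM in this assay, at which 2 of the 4 values shown sit.

As far as these compounds go, how large the step from compound 1 to compound 4 really is stays open, and with it whether the added methoxy changes anything beyond the scatter. Among these compounds, also open is how an amine or a carboxylic acid on this same aromatic carbon would read, and whether a hydroxy group there would bring a number like the one seen for compound 2.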